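Amide substituent change from compound 2 to compound 4

The source may report more compounds than this note shows. Statements on the series, on what has been measured and on what is new or still open speak of the compounds shown alone.

Going by the values given here, in an ADME assay on the whole organism (Rattus norvegicus, strain Wistar Han) for metabolic stability (on this read-out higher numbers stand for fast clearance and lower numbers for slow clearance), three compounds have numbers so far. Compound 1 `CCn1c(-c2cnc(C)nc2)nc2c(O[C@H]3CCN(C(=O)C4CC4)C3)ncnc21` gives 44 mL/min/kg, compound 3 `CCn1c(-c2ccc(C(F)(F)F)nc2)nc2c(O[C@H]3CCN(C(=O)[C@H]4C[C@@H](OC)C4)C3)ncnc21` gives 130 mL/min/kg, and compound 2 `CCn1c(-c2cnc(C)nc2)nc2c(N[C@H]3CCN(C(=O)C4CCC4)C3)ncnc21` gives 320 mL/min/kg. Compound 2 stands highest of the three: compound 3 is nearest, lower by a margin beyond the scatter, and compound 1 is furthest, lower by a wider margin that is also beyond the scatter. Among the compounds with values here, compound 4 `CCC(=O)N1CC[C@H](Nc2ncnc3c2nc(-c2cnc(C)nc2)n3CC)C1` is yet to be measured in this assay and differs from compound 2 in one place: ethyl in place of cyclobutyl on a carbonyl carbon No step between measured compounds matches this change, so its effect is open. In this assay a small move towards lower numbers is expected, within the scatter, as the step of a 1.3-fold lower number from compound 2 to compound 4 (0.11 log units; within the scatter). Compound 4 is therefore estimated at 250 mL/min/kg, with a range from 120 mL/min/kg to 500 mL/min/kg.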

Compound 4, clearance: 100 mL/min/kg
Estimate against measurement, compound 4: 2.5-fold (0.40 log units) above; measured number below the stated range.
By their numbers in this assay, from the lowest: compound 1; then compounds 4 and 3 (each within the scatter of the next); then compound 2.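

In this assay, going by these compounds alone, the group on this carbonyl carbon proves able to shift clearance: ethyl in place of cyclobutyl gives a 3.2-fold lower number from compound 2 to compound 4 (0.51 log units; beyond the scatter) and is the first single-place comparison. The step shows that this ring is not needed at this position, since the propanoyl amide compound 4 keeps the rest of compound 2 unchanged and still moves beyond the scatter. No evidence on the cause of this step is at hand. From the compounds shown here alone, whether loss of the ring or the shorter substituent carries the step stays open. Isopropyl, cyclopentyl or a longer chain such as butyl on the same carbonyl carbon would bear on that question.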